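Swapping the aryl on the piperazine nitrogen for 1-phenylethyl

This account rests on a few compounds, and the source may have more. Where it says the series, first, only, none or still open, it means among the compounds named here.

Measured so far:
Compound 1 `CCCn1c(=O)[nH]c2nc(-c3ccc(S(=O)(=O)N4CCN(c5ccc(F)cc5)CC4)cc3)[nH]c2c1=O`, 38%
Compound 2 `CCCn1c(=O)[nH]c2nc(-c3ccc(S(=O)(=O)N4CCN(c5ccc(Br)cc5)CC4)cc3)[nH]c2c1=O`, 29%
Compound 3 `CCCn1c(=O)[nH]c2nc(-c3ccc(S(=O)(=O)N4CCN(c5ccccc5F)CC4)cc3)[nH]c2c1=O`, 9%

In an assay on CHO cells for displacement of a labelled ligand from adenosine receptor A3 (Homo sapiens), read by scintillation counting, with a stated time of 45 min, tested at 1 uM, in the presence of a further agent that is not named here (a higher number here means more inhibition at the concentration tested (going by the name of the read-out), a lower number less inhibition), compound 3 stands lowest of the three, with the step of a number 29 percentage points lower from compound 1 to compound 3 (beyond the scatter) and the step of a number 20 percentage points lower from compound 2 to compound 3 (beyond the scatter) both going beyond the scatter, while a number 9 percentage points lower from compound 1 to compound 2 (within the scatter) stays within it. Compound 4 `CCCn1c(=O)[nH]c2nc(-c3ccc(S(=O)(=O)N4CCN(C(C)c5ccccc5)CC4)cc3)[nH]c2c1=O` differs from compound 3 in one place: 1-phenylethyl in place of 2-fluorophenyl on an amine nitrogen in a ring. Going by the values given here, both measured steps that end at compound 3 changed the group on the same ring nitrogen and were modest in size, so a change of that size is plausible here too; the direction is uncertain, as no measured step introduces 1-phenylethyl. Compound 4 is expected to return towards the values of compound 1 and compound 2, estimated at 25%, with a range from 5% to 50%, an estimated step of a number 16 percentage points higher from compound 3 to compound 4 (beyond the scatter).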

Compound 4, a percentage reported as inhibition, at one concentration (the size of the read-out at that concentration, not a potency): 0%
Compound 4: middle estimate off by 25 percentage points, on the high side; the whole stated range lies above it.
By their numbers in this assay, from the lowest: compounds 4 and 3 (each within the scatter of the next); then compounds 2 and 1 (each within the scatter of the next).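

In this assay the move to 1-phenylethyl on this ring nitrogen gives a number 9 percentage points lower from compound 3 to compound 4 (within the scatter) and so cannot be told apart from 2-fluorophenyl. Measured against 4-bromophenyl it gives a number 29 percentage points lower from compound 2 to compound 4 (beyond the scatter) and against 4-fluorophenyl it gives a number 38 percentage points lower from compound 1 to compound 4 (beyond the scatter) so only those two aryl groups stand clear of it. No measurement shown here explains this result.

Still open, on these data alone, is whether a plain benzyl group, without the methyl branch of 1-phenylethyl, would behave the same way. Also open, as far as these compounds go, is how a 4-methoxyphenyl group on this nitrogen would compare with 4-fluorophenyl.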